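This account rests on a few compounds, and the source may have more. Where it says the series, first, only, none or still open, it means among the compounds named here.

Measured compounds:
compound 1 `COc1cc2c(cc1OC)C(CC(=O)Nc1ccc(Cl)cc1)CC2`: 70%
compound 2 `COc1cc2c(cc1OC)C(CC(=O)Nc1ccc(Br)cc1)CC2`: 66.7%

In a functional assay on the whole organism (strain Wistar) for inhibition, with Rattus norvegicus as the target, read by paw edema, with a stated time of 24 h, at a dose of 100 mg/kg (on this read-out higher numbers stand for more inhibition at the one dose given (going by the name of the read-out) and lower numbers for less inhibition), compound 2 stands lowest of the two numbers, and the nearest is compound 1, because the step of a number 3.3 percentage points lower from compound 1 to compound 2 (within the scatter) lies within the scatter. Compound 3 `COc1cc2c(cc1OC)C(CC(=O)Nc1ccc([N+](=O)[O-])cc1)CC2` differs from compound 2 by nitro in place of bromo on an aromatic carbon. For the measured compounds named here, the only measured step, bromo in place of chloro, bears on this change but weakly, and no measured compound carries a nitro group. Compound 3 is therefore expected to give about 65%, between 50% and 80%, an expected step of a number 1.7 percentage points lower from compound 2 to compound 3 (within the scatter) that stays within the scatter.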

Compound 3, a percentage reported as inhibition, in the whole organism at one dose (the size of the read-out at that dose, not a potency): 43.3%
Estimate against measurement, compound 3: 21.7 percentage points above; measured number below the stated range.
By their numbers in this assay, from the lowest: compound 3; then compounds 2 and 1 (each within the scatter of the next).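

At this place on the ring, para to a large group, chloro and bromo stay within the scatter of each other, but nitro does not: a number 23.4 percentage points lower from compound 2 to compound 3 (beyond the scatter) and a number 26.7 percentage points lower from compound 1 to compound 3 (beyond the scatter) in this assay are both beyond it. The position therefore responds to what sits there, and the two halogens alone do not show the full range of that response. No measurement here accounts for the drop. Going by these compounds, whether an amine or a methoxy group at this place would stay with compound 1 and compound 2 or fall with compound 3 remains open.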